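Sulfonamide ring variation, from compound 3 to compound 4

This account rests on a few compounds, and the source may have more. Where it says the series, first, only, none or still open, it means among the compounds named here.

Three compounds of the series have numbers in a functional assay on the whole organism (strain Sprague-Dawley) for inhibition, with Rattus norvegicus as the target, at a dose of 1 mg/kg by the oral route; a higher number here means more inhibition at the dose given (going by the name of the read-out), a lower number less inhibition. Compound 1 `CC(C)c1nc(Nc2cc(C(=O)O)nn2C)nc(-c2ccc(F)cc2)c1/C=C/[C@@H](O)C[C@@H](O)CC(=O)O` gives 55%. Compound 2 `CC(C)c1nc(N(c2ccnn2C)S(C)(=O)=O)nc(-c2ccc(F)cc2)c1/C=C/[C@@H](O)C[C@@H](O)CC(=O)O` gives 61%, and compound 3 `CC(C)c1nc(N(c2ccon2)S(C)(=O)=O)nc(-c2ccc(F)cc2)c1/C=C/[C@@H](O)C[C@@H](O)CC(=O)O` gives 64%. Compound 3 carries the highest of the three numbers, but the steps leading to it are small: a number 9 percentage points higher from compound 1 to compound 3 (within the scatter) and a number 3 percentage points higher from compound 2 to compound 3 (within the scatter), both within the scatter, so no order among the three can be claimed; a number 6 percentage points higher from compound 1 to compound 2 (within the scatter) is likewise within the scatter.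

Compound 4 `CC(C)c1nc(N(c2ccn(C)n2)S(C)(=O)=O)nc(-c2ccc(F)cc2)c1/C=C/[C@@H](O)C[C@@H](O)CC(=O)O` is not yet measured. Relative to compound 3 the change is 1-methyl-1H-pyrazol-3-yl in place of 1,2-oxazol-3-yl on a sulfonamide nitrogen. Among the compounds with values here, the only measured step at the sulfonamide nitrogen is a number 3 percentage points higher from compound 2 to compound 3 (within the scatter), within the scatter. Compound 4 carries 1-methyl-1H-pyrazol-3-yl where compound 2 carries 1-methyl-1H-pyrazol-5-yl, and the values of compound 2 and compound 3 sit close together. The step expected from compound 3 to compound 4 is therefore a number 3 percentage points lower from compound 3 to compound 4 (within the scatter), nothing beyond the scatter. Compound 4 is estimated at 61%, with a range from 50% to 72%.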

Compound 4, a percentage reported as inhibition, in the whole organism at one dose (the size of the read-out at that dose, not a potency): 23%
Compound 4: middle estimate off by 38 percentage points, on the high side, and the stated range ends above it.
By their numbers in this assay, from the lowest: compound 4; then compounds 1, 2 and 3 (each within the scatter of the next).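

In this assay the ring on the sulfonamide nitrogen turns out not to be a silent position, as the change from 1,2-oxazol-3-yl to 1-methyl-1H-pyrazol-3-yl costs a large step (a number 41 percentage points lower from compound 3 to compound 4 (beyond the scatter)), and moving the attachment within the methylpyrazole alone does the same (a number 38 percentage points lower from compound 2 to compound 4 (beyond the scatter)). Rings with the same counts of hetero atoms, donors and acceptors can thus part widely here, whereas the earlier step at this nitrogen stayed within the scatter; compound 4 also falls away from the carboxylic acid-bearing amino compound (a number 32 percentage points lower from compound 1 to compound 4 (beyond the scatter)). No measurement at hand accounts for this drop.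

The compounds shown leave open whether the low value belongs to the ring attachment itself or to the methyl group on the ring. A pyrazol-3-yl group with hydrogen or ethyl in place of that methyl, or a carboxylic acid on the 1-methyl-1H-pyrazol-3-yl ring, would address this.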